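The compounds below may be only part of what the source reports. "The series", "measured", "known", "first", "only" and "open" are said of these compounds alone.

Among the measured compounds shown here, compound 3 `COc1ccc(C(=O)c2cc(OC)c(OC)c(OC)c2)cc1NC(=O)/C=C/c1ccc(F)c(F)c1` stands, in a functional assay on B16 cells (Mus musculus) for cytotoxicity, read by MTT assay, with a stated time of 72 h (on this read-out higher numbers stand for weaker inhibition and lower numbers for stronger inhibition), at 6500 nM, the second highest of the three numbers known so far. Its nearest neighbour is compound 1 `COc1ccc(/C=C/C(=O)Nc2cc(C(=O)c3cc(OC)c(OC)c(OC)c3)ccc2OC)cc1`, which gives 8700 nM in this assay, and the step of a 1.3-fold lower number from compound 1 to compound 3 (0.13 log units; within the scatter) lies within the scatter. Its furthest neighbour is compound 2 `COc1ccc(C(=O)c2cc(OC)c(OC)c(OC)c2)cc1NC(=O)/C=C/c1ccc(F)cc1`, which gives 400 nM; here the step of a 16-fold higher number from compound 2 to compound 3 (1.21 log units; beyond the scatter) is large.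

Compound 4 `COc1ccc(C(=O)c2cc(OC)c(OC)c(OC)c2)cc1NC(=O)/C=C/c1ccc([N+](=O)[O-])cc1` differs from compound 3 by the change (4-nitrophenyl in place of 3,4-difluorophenyl on a double-bonded chain carbon bound to a double-bonded chain carbon). For the measured compounds named here, two measured steps bear on this position. Going by the values given here, the step of a 22-fold lower number from compound 1 to compound 2 (1.34 log units; beyond the scatter) shows that a change of the single group on the far aromatic ring can move the number a great deal, while the step of a 1.3-fold lower number from compound 1 to compound 3 (0.13 log units; within the scatter) shows that a change of a similar scale can also leave it essentially where it was. Among the compounds with values here, no measured compound carries a nitro group, so the direction for compound 4 rests on weak ground; the two large steps argue only that a substantial move in either direction is possible. Compound 4 is therefore expected to land between the extremes seen, with the step of a 2.2-fold lower number from compound 3 to compound 4 (0.34 log units; beyond the scatter) most likely a moderate decrease. The estimate for compound 4 in this assay is 3000 nM, within a range from 400 nM to 15000 nM.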

Compound 4, half-maximal inhibitory concentration: 6400 nM
For compound 4 the middle estimate is 2.1-fold (0.33 log units) below the measured one; low and high end bracket the measured number.
By their numbers in this assay, from the lowest: compound 2; then compounds 4, 3 and 1 (each within the scatter of the next).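

In this assay the change to 4-nitrophenyl on a double-bonded chain carbon bound to a double-bonded chain carbon leaves the number where it was, with a 1.0-fold lower number from compound 3 to compound 4 (0.01 log units; within the scatter) and likewise a 1.4-fold lower number from compound 1 to compound 4 (0.13 log units; within the scatter), so 4-methoxyphenyl, 3,4-difluorophenyl and 4-nitrophenyl now read alike at this place. Among the compounds shown here, compound 2, with its single fluoro group, is therefore the only one of the four that stands apart, as a 16-fold higher number from compound 2 to compound 4 (1.20 log units; beyond the scatter) shows, and the large step seen earlier between compound 2 and compound 3 is no longer an isolated contrast but the difference between one compound and a cluster of three. Nothing available here offers an explanation for why this one compound departs from the others.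

The compounds shown leave open whether the low number of compound 2 is particular to the single fluoro group or would also appear with a single chloro, a nitrile or a hydroxyl at that ring position. They also leave open how an amine or a carboxylic acid on that ring would read, and whether any change elsewhere on the shared core would alter this picture.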